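Aryl carbamate swap on the dihydropyridinone series

The compounds below may be only part of what the source reports. "The series", "measured", "known", "first", "only" and "open" are said of these compounds alone.

Measured so far:
Compound 1, `CCOc1cc(=O)n(CCCO)c2c1CC(CC=C(C)C)C(C)(C)C2`, in a functional assay on PANC-1 cells (Homo sapiens) for inhibition, read by MTT assay, with a stated time of 24 h, tested at 10 uM (on this read-out higher numbers stand for more inhibition at the one concentration tested (going by the name of the read-out) and lower numbers for less inhibition), gives 16.6%.
Compound 2, `COc1ccc(NC(=O)Oc2cc(=O)n(CCCO)c3c2CC(CC=C(C)C)C(C)(C)C3)cc1`, in this assay gives 0%.
Compound 3, `COc1ccc(NC(=O)Oc2cc(=O)n(CCCO)c3c2CC(C/C=C(\C)CCC=C(C)C)C(C)(C)C3)cc1`, in this assay gives 0%.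

Compound 3 sits level with compound 2 at the digits read, and together they are the lowest two numbers of the three; compound 1 stands furthest from compound 3, its number higher by a number 16.6 percentage points lower from compound 1 to compound 2 (beyond the scatter) read in reverse, while no change at the digits printed from compound 2 to compound 3 (within the scatter) places compound 3 within the scatter of compound 2.

Compound 4, `CC(C)=CCC/C(C)=C/CC1Cc2c(OC(=O)Nc3ccc(Cl)c(Cl)c3)cc(=O)n(CCCO)c2CC1(C)C`, is the next member. Against compound 3 the change is 3,4-dichlorophenyl in place of 4-methoxyphenyl on an amide-type nitrogen.

Neither measured step touches this part of the molecule: the step of a number 16.6 percentage points lower from compound 1 to compound 2 (beyond the scatter) exchanged the ethyl on the ring oxygen for the whole carbamoyl unit, and the step of no change at the digits printed from compound 2 to compound 3 (within the scatter) altered the side chain at the other end. Among the measured compounds shown here, no step varies the aryl group on the carbamate nitrogen, so the bearing of the measured steps on this change is indirect at best.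

Given that both carbamates so far sit at the floor of the read-out, compound 4 is expected to stay there as well, with a step of about a number 3 percentage points higher from compound 3 to compound 4 (within the scatter), that is none beyond the scatter. Compound 4 is therefore estimated at 3%, within the range 0% to 15%.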

Compound 4, a percentage reported as inhibition, at one concentration (the size of the read-out at that concentration, not a potency): 0%
Compound 4: the middle estimate sits 3 percentage points above what was measured; measured number inside the range.
By their numbers in this assay, from the lowest: compounds 2, 3 and 4 (each within the scatter of the next); then compound 1.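

Working notes on the carbamate aryl group: on the amide-type nitrogen, 3,4-dichlorophenyl in place of 4-methoxyphenyl gives no change at the digits printed from compound 3 to compound 4 (within the scatter) in this assay, and this is the only step among the compounds shown that varies this aryl group. The methoxy-bearing ring and the dichloro-bearing ring therefore cannot be told apart on this read-out at the one concentration tested, so with compound 4 at 0% the series now holds three carbamates at the same printed value, with two different aryl groups and two different side chains. Nothing available explains this flat result or the position of the carbamates relative to the ethyl ether compound 1.

Still open, from the compounds shown here alone, is whether any other group on this nitrogen, such as a 4-carboxyphenyl, a 4-(dimethylamino)phenyl, a pyridinyl or a plain alkyl chain, would give a number distinguishable from that of compound 4. Also open, going by these compounds, is how the longer side chain of compound 3 behaves on the ethyl ether, and whether a propyl or benzyl group in place of that ethyl changes the number of compound 1, 16.6%.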